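Working notes on a cytotoxicity series, three limits so far

The source may hold more compounds than are shown below. What is called first, only, known or untested is meant among the compounds shown, and "the series" means these compounds.

Measured compounds:
compound 1 `COc1ccc(-n2ccc(=O)c(C(=O)Nc3ccc(Oc4ccnc5[nH]ccc45)c(F)c3)n2)cc1` — > 60000 nM
compound 2 `O=C(Nc1ccc(Oc2ccnc3[nH]ccc23)c(F)c1)c1nn(-c2ccc(Br)cc2)ccc1=O` — > 60000 nM
compound 3 `COc1ccc(-n2ccc(=O)c(C(=O)Nc3ccc(Oc4ccnc5c4ccn5C)cc3)n2)cc1` — > 60000 nM

In a functional assay on A549 cells (Homo sapiens) for cytotoxicity, read by MTT assay, with a stated time of 72 h (a higher number here means a weaker inhibitor, a lower number a stronger inhibitor), compound 1 gives > 60000 nM, which is a limit of the assay and not a number. Compound 2 gives > 60000 nM in this assay, again only a limit. Compound 3 gives > 60000 nM in this assay, also a limit.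

Compound 1 and compound 2 differ in one place, (bromo in place of methoxy on an aromatic carbon). The step that the two limits leave unreadable from compound 1 to compound 2 cannot be read, as both ends sit at the same limit: the limit of > 60000 nM in this assay, at which 3 of the 3 values shown sit. The cores of compound 1 and compound 3 differ, but that difference is not broken down here.

Compound 4 `Cn1ccc2c(Oc3ccc(NC(=O)c4nn(-c5ccc(Br)cc5)ccc4=O)cc3)ccnc21` has not yet been measured. It differs from compound 3 by bromo in place of methoxy on an aromatic carbon, the same change as from compound 1 to compound 2; the place of the change is the same in both pairs, and among these compounds the change occurs twice in all.

For the measured compounds named here, for compound 4 the step of a number no higher from compound 3 to compound 4 (the limit leaves the size open) in this assay is expected to be unreadable in the same way, which rests on the fact that compound 1, compound 2 and compound 3 all stand at the limit of > 60000 nM in this assay, at which 3 of the 3 values shown sit, and that the first instance of this change gave a step that the two limits leave unreadable from compound 1 to compound 2. Compound 4 is therefore estimated at 60000 nM, between 30000 nM and 120000 nM, with a high chance that the assay again reports only its limit.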

Compound 4, half-maximal inhibitory concentration: 59400 nM
Beside the measured number, compound 4's estimate is 1.0-fold (0.00 log units) above it, and the stated range covers the measured number.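

In this assay, the change from 4-methoxyphenyl to 4-bromophenyl on the core of compound 3 gives a number no higher from compound 3 to compound 4 (the limit leaves the size open), and compound 4 gives 59400 nM, a measured number. Compound 3 gives > 60000 nM, which is a limit of the assay and not a number, so this step has a direction at most and no size, and the earlier instance of the change, with compound 1 and compound 2 both at a limit, cannot be read either. The two instances therefore cannot be compared in size, and nothing here shows that the change carries over from one core to the other with the same result, or that it has any real effect at all, with the series sitting almost wholly at one ceiling: the limit of > 60000 nM in this assay, at which 3 of the 4 values shown sit.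

The compounds shown leave open how an amine or a carboxylic acid in the same place, on that aromatic carbon, would read in this assay, and whether any group there would bring a value clearly away from the limit. They also leave open what the difference between the core of compound 1 and the core of compound 3 contributes, which no pair shown isolates.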